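Sulfonyl aryl exchange on the fluorobenzamide sulfonamide series

This account rests on a few compounds, and the source may have more. Where it says the series, first, only, none or still open, it means among the compounds named here.

Compound 3 `O=C(NCc1ccc(CNS(=O)(=O)c2ccc3c(c2)CCO3)cc1)c1ccc(F)cc1` stands second highest of the three numbers in an assay on MDA-MB-231 cells for binding affinity to C-X-C chemokine receptor type 4 (Homo sapiens), read by fluorescence and microscopy, with stated times of 10 min and 30 min; on this read-out lower numbers stand for an effect already at smaller amounts and higher numbers for an effect only at larger amounts of compound: compound 3 gives 10 nM. Its nearest neighbour is compound 1 `CCN(CC)Cc1ccc(S(=O)(=O)NCc2ccc(CNC(=O)c3ccc(F)cc3)cc2)cc1`, which gives 1 nM, and the furthest is compound 2 `O=C(NCc1ccc(CNS(=O)(=O)c2ccc(-c3ccc(F)cc3)cc2)cc1)c1ccc(F)cc1`, which gives 100 nM. For the measured compounds named here, the only single-point step measured so far, a 100-fold higher number from compound 1 to compound 2 (2.00 log units; beyond the scatter), shows that the group on the sulfonyl sulfur can move the read-out strongly, though that step exchanged a basic amine-bearing group for an aryl and is not the same kind of change as the one below. Compound 2 and compound 3 both carry a neutral aryl there; their two values alone show compound 3 at the lower number.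

Compound 4 `O=C(NCc1ccc(CNS(=O)(=O)c2cccc3ccccc23)cc1)c1ccc(F)cc1` differs from compound 3 in one place: a group of 10 heavy atoms (10 carbon; 2 six-membered aromatic rings of carbon only) in place of a group of 9 heavy atoms (8 carbon, 1 oxygen; one five-membered non-aromatic ring with 1 hetero atom, one six-membered aromatic ring of carbon only), on a sulfonyl sulfur. Both groups are bicyclic, but the entering naphthalen-1-yl has no hydrogen-bond acceptor where the leaving group had one. Going by the values given here, no measured step covers this exact exchange. A step toward a higher number, smaller than the step from compound 1 to compound 2 and possibly within the scatter, is expected: a 3.0-fold higher number from compound 3 to compound 4 (0.48 log units; beyond the scatter). Compound 4 is estimated at 30 nM, within 8 nM to 150 nM.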

Compound 4, effective concentration (reported as EC, without a stated level of effect): 1000 nM
For compound 4 the middle estimate is 33-fold (1.52 log units) below the measured one; the measured number lies above the stated range.
By their numbers in this assay, from the lowest: compound 1; then compound 3; then compound 2; then compound 4.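

In this assay, the exchange on the sulfonyl sulfur gives a 100-fold higher number from compound 3 to compound 4 (2.00 log units; beyond the scatter), so a large change at this position does not depend on removing the (diethylamino)methyl group: both groups here carry no net charge, yet the step matches in size a 100-fold higher number from compound 1 to compound 2 (2.00 log units; beyond the scatter). The position therefore separates even two bicyclic groups, and among the groups without net charge compound 3 gives 10 nM, compound 2 gives 100 nM and compound 4 gives 1000 nM. Nothing available explains the size of this step.

The exchange replaces the ring system and removes the hydrogen-bond acceptor in a single move, so the compounds shown cannot say which of the two changes accounts for the step. Naphthalen-2-yl would test the attachment point of the same ring system, while methoxyphenyl would test an oxygen on a single aromatic ring, and a piperidin-1-ylmethyl group would show whether the low number of compound 1 extends beyond its (diethylamino)methyl group.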